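The source may hold more compounds than are shown below. What is called first, only, known or untested is meant among the compounds shown, and "the series" means these compounds.

Compound 1 `[SeH]c1nc2ccccc2s1` gives no number in a functional assay on PC-3 cells (Homo sapiens) for cytotoxicity, read by MTT assay, with a stated time of 72 h (on this read-out lower numbers stand for stronger inhibition of growth and higher numbers for weaker inhibition of growth), but only > 50000 nM, which is a limit, namely (the limit of > 50000 nM in this assay, at which 1 of the 2 values shown sits). Compound 2 `CSc1ccc2ccccc2n1` in this assay gives 87000 nM, the only number shown in the series. Compound 3 `C[Se]c1ccc2ccccc2n1` differs from compound 2 by a group of 2 heavy atoms (1 carbon, 1 selenium; no ring) in place of a group of 2 heavy atoms (1 carbon, 1 sulfur; no ring), on an aromatic carbon. For the measured compounds named here, no measured step covers this exchange, and in this assay no step beyond the usual scatter is expected in either direction. The step expected from compound 2 to compound 3 is a 1.5-fold lower number from compound 2 to compound 3 (0.16 log units; within the scatter). For compound 3 the estimate is 60000 nM, between 20000 nM and 150000 nM.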

Compound 3, concentration for 50% growth inhibition: 83600 nM
The estimate for compound 3 lay 1.4-fold (0.14 log units) below the measured number; the measured number falls inside the stated range.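

In this assay, putting the selenium-bearing group in place of methylsulfanyl, on an aromatic carbon next to the ring nitrogen, gives a 1.0-fold lower number from compound 2 to compound 3 (0.02 log units; within the scatter). For the compounds shown here, this is the first measured exchange at this position, and for these two compounds selenium and sulfur are interchangeable on this read-out. Nothing in the data shown bears on why.

From the compounds shown here alone, whether an amine, a carboxylic acid or a longer chain at this position would move the number beyond the scatter remains open. So does whether the same exchange stays this flat on another core.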